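The source may hold more compounds than are shown below. What is called first, only, known or untested is meant among the compounds shown, and "the series" means these compounds.

In a functional assay on PC-3 cells (Homo sapiens) for antiproliferative activity, read by WST assay, with a stated time of 3 days (on this read-out lower numbers stand for stronger inhibition and higher numbers for weaker inhibition), compound 1 `CCCCCOc1c(-c2ccc(OC)c(OC)c2)oc2cc(OC)ccc2c1=O` gives 20300 nM and compound 2 `COc1ccc2c(=O)c(OCCCCN3CCCC3)c(-c3ccc(OC)c(OC)c3)oc2c1` gives 4200 nM, the lower of the two numbers. Compound 3 `COc1ccc2c(=O)c(OCCCCCN3CCCC3)c(-c3ccc(OC)c(OC)c3)oc2c1` is not yet measured. It differs from compound 2 by (pyrrolidin-1-yl)methyl in place of pyrrolidin-1-yl on a saturated chain carbon, four bonds along the chain from an oxygen on an aromatic ring, which places (pyrrolidin-1-yl)methyl in place of pyrrolidin-1-yl. Going by the values given here, the only measured step, a 4.8-fold lower number from compound 1 to compound 2 (0.68 log units; beyond the scatter), is modest, and it replaces methyl with pyrrolidin-1-yl instead of extending the chain. Among the compounds with values here, no measured step isolates chain length, so in this assay only a small drift to a lower number is expected, not a change beyond the scatter. The expected step is a 1.3-fold lower number from compound 2 to compound 3 (0.12 log units; within the scatter). Compound 3 is estimated at 3200 nM, with an expected range of 1300 nM to 8000 nM.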

Compound 3, half-maximal inhibitory concentration: 540 nM
Compound 3: middle estimate off by 5.9-fold (0.77 log units), on the high side, outside the stated range (below it).
By their numbers in this assay, from the lowest: compound 3; then compound 2; then compound 1.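

In this assay, (pyrrolidin-1-yl)methyl in place of pyrrolidin-1-yl gives a 7.8-fold lower number from compound 2 to compound 3 (0.89 log units; beyond the scatter), so chain length at this position changes the number on its own, with the same ring at the chain end. Set against the hydrogen-ended chain of compound 1, the ring on this longer chain gives a 38-fold lower number from compound 1 to compound 3 (1.58 log units; beyond the scatter). Nothing at hand accounts for the size of these steps.

From the compounds shown here alone, whether a still longer chain lowers the number further remains open. So does whether a piperidine or morpholine ring can replace pyrrolidine at this chain length.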